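Swapping a hydroxypropyl chain for a cyanophenyl ring

The source may report more compounds than this note shows. Statements on the series, on what has been measured and on what is new or still open speak of the compounds shown alone.

Compound 2 `COc1ccc2c(c1)NC(=O)CN2c1nc(NCCCO)nc2ccccc12` is the strongest growth inhibitor of the three measured compounds, its steps to both others lying beyond the scatter. In a functional assay on MCF7 cells (Homo sapiens) for inhibition, read by sulforhodamine B assay, with a stated time of 48 h (a higher number here means a weaker inhibitor of growth, a lower number a stronger inhibitor of growth), compound 2 gives 7.43 nM. Compound 1 `COc1ccc2c(c1)NC(=O)CN2c1nc(COC(C)=O)nc2ccccc12` gives 33 nM in this assay, and compound 3 `COc1ccc2c(c1)NC(=O)CN2c1nc(NCc2ccncc2)nc2ccccc12` gives 71.8 nM. The step of a 4.4-fold lower number from compound 1 to compound 2 (0.65 log units; beyond the scatter) and the step of a 9.7-fold higher number from compound 2 to compound 3 (0.99 log units; beyond the scatter) are both modest, and the second is the one that bears on the new change, since it also exchanges a short chain carrying a hydroxyl for an aromatic ring.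

Compound 4 `COc1ccc2c(c1)NC(=O)CN2c1nc(Nc2ccc(C#N)cc2)nc2ccccc12` differs from compound 2 in this way: 4-cyanophenyl in place of 3-hydroxypropyl on a nitrogen on an aromatic ring. The group that leaves carries one hydrogen-bond donor; the group that enters carries none and brings a six-membered aromatic ring with a nitrile. Given the step of a 9.7-fold higher number from compound 2 to compound 3 (0.99 log units; beyond the scatter), a step of similar size and direction is expected here, giving a higher number in this assay. Compound 4 is therefore expected to give about 60 nM, within the range 20 nM to 200 nM, which means the estimated step of an 8.1-fold higher number from compound 2 to compound 4 (0.91 log units; beyond the scatter).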

Compound 4, concentration for 50% growth inhibition: 9.19 nM
For compound 4 the middle estimate is 6.5-fold (0.81 log units) above the measured one; measured number outside the range, below it.
By their numbers in this assay, from the lowest: compounds 2 and 4 (each within the scatter of the next); then compound 1; then compound 3.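

At this nitrogen in this assay, a directly attached 4-cyanophenyl ring and a 3-hydroxypropyl chain give values that cannot be told apart (a 1.2-fold higher number from compound 2 to compound 4 (0.09 log units; within the scatter)), so the hydrogen-bond donor on the chain is not needed for a low number in this pair. An aromatic ring in this region does not by itself bring the higher number seen with the (pyridin-4-yl)methyl group (a 7.8-fold lower number from compound 3 to compound 4 (0.89 log units; beyond the scatter)), and the (4-cyanophenyl)amino group also compares well with acetoxymethyl on the aromatic carbon (a 3.6-fold lower number from compound 1 to compound 4 (0.56 log units; beyond the scatter)). No measurement shown here explains these differences.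

On these data alone, what the nitrile contributes remains open. An unsubstituted phenyl ring or a 4-methoxyphenyl ring on the same nitrogen would help to separate the contribution of the nitrile from that of the ring.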